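This account rests on a few compounds, and the source may have more. Where it says the series, first, only, none or still open, it means among the compounds named here.

Measured so far in a functional assay on K562 cells (Homo sapiens) for cytotoxicity, read by MTT assay, with a stated time of 72 h (on this read-out higher numbers stand for weaker inhibition and lower numbers for stronger inhibition), are three compounds:
- compound 1 `CC(C)(C)C1=CC(=O)C=C(NCCC(=O)O)C1=O` gives 67000 nM
- compound 2 `CC1=CCC[C@H]2[C@](C)(CC3=CC(=O)C=CC3=O)[C@@H](C)CC[C@]12C` gives 17100 nM
- compound 3 `CC(C)(C)C1=CC(=O)C=CC1=O` gives 15500 nM

Compound 3 (15500 nM) lies within the scatter of compound 2 (17100 nM). Compound 1 (67000 nM) stands clearly apart from compound 3, beyond the scatter. The next compound is compound 4 `C[C@H](NC1=CC(=O)C=C(C(C)(C)C)C1=O)C(=O)O`, which differs from compound 3 by a single change ((1-carboxyethyl)amino in place of hydrogen on a double-bonded ring carbon): (1-carboxyethyl)amino in place of hydrogen on a double-bonded ring carbon.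

Among the compounds with values here, only one measured step bears on this (a 4.3-fold lower number from compound 1 to compound 3 (0.64 log units; beyond the scatter)). There, hydrogen replaces (2-carboxyethyl)amino on a double-bonded ring carbon, a modest step beyond the scatter. The change to compound 4 runs the opposite way, with a different carboxyethyl chain, so a step of similar size toward a higher number seems likely. Within the data shown here, no measurement yet compares the two chains, which leaves the size uncertain. The expected change in this assay is a 3.5-fold higher number from compound 3 to compound 4 (0.55 log units; beyond the scatter) by this estimate. Compound 4 is expected at about 55000 nM with an estimated range from 25000 nM to 120000 nM in this assay.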

Compound 4, half-maximal inhibitory concentration: 77600 nM
The estimate for compound 4 lay 1.4-fold (0.15 log units) below the measured number; measured number inside the range.
By their numbers in this assay, from the lowest: compounds 3 and 2 (each within the scatter of the next); then compounds 1 and 4 (each within the scatter of the next).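

In this assay, (1-carboxyethyl)amino in place of hydrogen on a double-bonded ring carbon gives a 5.0-fold higher number from compound 3 to compound 4 (0.70 log units; beyond the scatter), so a second chain at this position also goes with a higher number, not only the (2-carboxyethyl)amino group of compound 1. With 1-carboxyethyl in place of 2-carboxyethyl on the amine nitrogen, the result is a 1.2-fold higher number from compound 1 to compound 4 (0.06 log units; within the scatter), which lies within the scatter, so this assay does not separate the two chains. Nothing at hand explains the higher number with either chain.

From the compounds shown here alone, whether the step follows the amine nitrogen or the carboxylic acid remains open, and an amine carrying a plain ethyl chain at this position would speak to that. Also open, going by these compounds, are the effect of a longer chain ending in a carboxylic acid and of the opposite configuration at the stereocentre of the 1-carboxyethyl group.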